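This account rests on a few compounds, and the source may have more. Where it says the series, first, only, none or still open, it means among the compounds named here.

In an ADME assay (Mus musculus, strain C57BL/6) for metabolic stability, read by HPLC, with a stated time of 12 h (on this read-out lower numbers stand for a shorter-lived compound and higher numbers for a longer-lived compound), compound 1 `O=C(O)[C@@H](CO)NC(=O)[C@H]1C[C@@H](O)CN1` gives > 12 h, which is a limit of the assay and not a number. Compound 2 `O=C(O)[C@H](CO)NC(=O)[C@H]1C[C@@H](O)CN1` gives > 12 h, which is also a limit. Both results therefore stand at the same point: the limit of > 12 h in this assay, at which 2 of the 2 values shown sit. Compound 3 `O=C(O)[C@H](CO)NC(=O)[C@@H]1C[C@H](O)CN1` departs from compound 2 as follows: the two compounds have the same atoms and bonds and differ only in configuration as drawn: 2 of 3 stereo elements differ; a stereocentre at a saturated ring carbon is drawn R in compound 2 and S in compound 3; a stereocentre at a saturated ring carbon is drawn R in compound 2 and S in compound 3. Within the data shown here, the only measured step bearing on this is a step that the two limits leave unreadable from compound 1 to compound 2, and what it offers is the fact that compounds 1 and 2 differ only in the configuration as drawn. That step changed a stereocentre at a saturated chain carbon, whereas both changes here lie at saturated ring carbons, so it is only a loose guide. With nothing but a step that the two limits leave unreadable from compound 1 to compound 2 to go on, no step beyond the scatter is expected in this assay, in either direction. The estimated step is a step that the limit leaves unreadable from compound 2 to compound 3. Compound 3 is expected at about 14 h, with an estimated range from 7 h to 28 h.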

Compound 3, half-life: 1.22 h
Beside the measured number, compound 3's estimate is 11-fold (1.06 log units) above it, and the stated range ends above it.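

In this assay, inverting both stereocentres at saturated ring carbons gives an at least 9.8-fold lower number from compound 2 to compound 3 (0.99 log units; beyond the scatter), and inverting all the stereocentres, which yields the mirror image, gives an at least 9.8-fold lower number from compound 1 to compound 3 (0.99 log units; beyond the scatter). Among these compounds, the earlier step between compound 1 and compound 2 cannot be read, since both results are limits of the assay, so this is the first sign that configuration alone can move this read-out beyond the scatter. The shift must lie in the drawn configuration, because the atoms and bonds stay the same: the fact that compounds 2 and 3 differ only in the configuration as drawn

Which of the two ring stereocentres carries the drop stays open, since both change together here, and the chain stereocentre's part in it cannot be told. Also open, as far as these compounds go, is how compound 3's ring configuration would behave with a methyl ester in place of the carboxylic acid.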